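The compounds below may be only part of what the source reports. "The series", "measured", "known", "first", "only" and "open" are said of these compounds alone.

Measured compounds in a functional assay on aorta (Rattus norvegicus, strain Wistar) for inhibition, with a stated time of 60 min; on this read-out lower numbers stand for an effect already at smaller amounts and higher numbers for an effect only at larger amounts of compound:
compound 1 `COc1cc(-c2nc3cc([N+](=O)[O-])ccc3[nH]2)ccc1O` gives 1810 nM
compound 2 `COc1cc(-c2nc3cc(C(F)(F)F)ccc3[nH]2)ccc1O` gives 34800 nM
compound 3 `CCOc1ccccc1-c1nc2cc(C(F)(F)F)ccc2[nH]1` gives 549000 nM

Compound 1 and compound 2 share one core and differ in a single place: nitro in place of trifluoromethyl on an aromatic carbon. The step measured for this change is a 19-fold lower number from compound 2 to compound 1 (1.28 log units; beyond the scatter).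

Compound 3 carries a different core. How the core of compound 3 differs from the core of compound 2 is not broken down here; the two values simply show compound 3 at the higher number of the pair, and compound 3 is the highest number of the three, furthest from compound 1.

Compound 4 `CCOc1ccccc1-c1nc2cc([N+](=O)[O-])ccc2[nH]1` has not been measured in this assay. It differs from compound 3 in one place: nitro in place of trifluoromethyl on an aromatic carbon. The place of this change reads the same, word for word, as the place of the change from compound 2 to compound 1, so it is the same change made a second time, now on the other core. Among the compounds with values here, only one measured instance of the change exists, and the two cores differ in a way not counted here, so the transfer carries uncertainty.

The step from compound 3 to compound 4 is estimated at a 14-fold lower number from compound 3 to compound 4 (1.14 log units; beyond the scatter). This expectation rests on the step of a 19-fold lower number from compound 2 to compound 1 (1.28 log units; beyond the scatter), assumed to carry over to the second core in size. For compound 4 in this assay the estimate is 40000 nM, expected to lie between 8000 nM and 200000 nM.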

Compound 4, half-maximal effective concentration: 3710 nM
The estimate for compound 4 lay 11-fold (1.03 log units) above the measured number, outside the stated range (below it).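

In this assay the replacement of trifluoromethyl by nitro lowers the number on the second core as well, and the new step is a 150-fold lower number from compound 3 to compound 4 (2.17 log units; beyond the scatter) on that core. The direction of the change therefore holds on both cores shown, but its size does not carry over, so in this series a step measured on one core indicates the direction on the other and gives no dependable size. Two cores are only two instances, so they set no rule for further cores and do not show what separates the two steps, which compare as follows: the same change on two cores in this assay, a 19-fold lower number (1.28 log units; beyond the scatter) from compound 2 to compound 1 and a 150-fold lower number (2.17 log units; beyond the scatter) from compound 3 to compound 4, 7.7-fold (0.89 log units) apart, beyond the scatter of two such steps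

Still open, on these data alone, is which difference between the two cores goes with the larger step, and whether a third core would give a step near either of these two or outside both. Also open, as far as these compounds go, is how the steps would run on either core if the same place on the six-membered aromatic ring carried another group, such as a nitrile, an amine or a carboxylic acid, in place of nitro or trifluoromethyl.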